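This account rests on a few compounds, and the source may have more. Where it says the series, first, only, none or still open, it means among the compounds named here.

In an ADME assay on HepG2 cells (Homo sapiens) for cytotoxicity (on this read-out lower numbers stand for higher toxicity in this test and higher numbers for lower toxicity in this test), compound 3 `CN1CCN(CC#Cc2cc3c(Nc4ccc(OCc5cccc(F)c5)c(Cl)c4)ncnc3s2)CC1` gives 15 uM and serves as the reference point here. Compound 1 `CC(C)(C)CC#Cc1cc2ncnc(Nc3ccc(OCc4cccc(F)c4)c(Cl)c3)c2s1` gives 29.3 uM on the same read-out, and these two numbers lie within the scatter of each other. For compound 2 `COCC#Cc1cc2ncnc(Nc3ccc(OCc4cccc(F)c4)c(Cl)c3)c2s1` the assay returned only a limit, > 33 uM as its reported result.

Compound 4 `CN(C)CC#Cc1cc2c(Nc3ccc(OCc4cccc(F)c4)c(Cl)c3)ncnc2s1` keeps the core of compound 3 and differs at the end of the chain: dimethylamino in place of 4-methylpiperazin-1-yl on a saturated chain carbon bound to a triple-bonded carbon. In short, it carries dimethylamino in place of 4-methylpiperazin-1-yl on a saturated chain carbon bound to a triple-bonded carbon.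

Among the measured compounds shown here, the only measured step at this kind of place is an at least 1.1-fold higher number from compound 1 to compound 2 (0.05 log units; that floor lies within the scatter), with methoxy in place of tert-butyl. Its floor lies within the scatter, but a floor does not fix the size of a step. It also comes from compounds whose core is arranged differently from that of compound 3 and compound 4, and neither of its groups is involved in the present exchange. It therefore offers only loose guidance, and no step beyond the scatter is expected in this assay, with no clear direction. The expected change is a 1.1-fold higher number from compound 3 to compound 4 (0.05 log units; within the scatter) and remains within the scatter. For compound 4 the estimated value is 17 uM, with an expected range from 7 uM to 35 uM in this test.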

Compound 4, half-maximal toxic concentration: > 32 uM
Compound 4 was reported as a limit; the forecaster's own chance of this, stated with the estimate: 10%; middle value at least 1.8-fold (0.27 log units) away from the limit.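

In this assay, the exchange on a saturated chain carbon bound to a triple-bonded carbon now gives a step beyond the scatter, with dimethylamino in place of 4-methylpiperazin-1-yl: an at least 2.1-fold higher number from compound 3 to compound 4 (0.32 log units; beyond the scatter). The earlier step at this kind of place, an at least 1.1-fold higher number from compound 1 to compound 2 (0.05 log units; that floor lies within the scatter), had a floor within the scatter, so it did not show that the group at the end of this chain can shift this read-out beyond the scatter. The new step can be read only as a floor, because the result for compound 4 is a limit: the limit of > 32 uM in this assay, at which 1 of the 4 values shown sits.

The compounds shown leave open whether another amine at this place, such as diethylamino or piperidin-1-yl, would also stand apart from compound 3 in this assay, and so whether the open-chain form of the amine or the smaller size of the group goes with the step. They also leave open whether dimethylamino in place of 4-methylpiperazin-1-yl would give a step of similar size on the core of compound 1.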